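This account rests on a few compounds, and the source may have more. Where it says the series, first, only, none or still open, it means among the compounds named here.

Compound 1 `C[C@H](O)[C@@H](CCc1cccc(-c2nccs2)c1)n1cnc2c(N)ncnc21`: 2.6 nM in an assay on isolated protein for inhibition of adenosine deaminase (Bos taurus), with a stated time of 5 min; a higher number here means a weaker inhibitor, a lower number a stronger inhibitor.
Compound 2 `C[C@H](O)[C@@H](CCc1cccc(C(=O)O)c1)n1cnc2c(N)ncnc21`: 53 nM in this assay.

Going by the values given here, compound 2 stands at the higher of the two numbers in this assay, with compound 1 as its only neighbour. Compound 3 `C[C@H](O)[C@@H](CCc1cccc(CO)c1)n1cnc2c(N)ncnc21` differs from compound 2 by hydroxymethyl in place of carboxy on an aromatic carbon. Among the compounds with values here, the one measured step that bears on this is a 20-fold higher number from compound 1 to compound 2 (1.31 log units; beyond the scatter), a large loss on going to carboxy. Hydroxymethyl is a different change, so the step from compound 2 to compound 3 in this assay is expected to be a 2.7-fold lower number from compound 2 to compound 3 (0.42 log units; beyond the scatter), toward a lower number. Compound 3 is therefore estimated at 20 nM, within 5 nM to 100 nM.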

Compound 3, inhibition constant: 4.6 nM
For compound 3 the middle estimate is 4.3-fold (0.64 log units) above the measured one, outside the stated range (below it).
By their numbers in this assay, from the lowest: compounds 1 and 3 (each within the scatter of the next); then compound 2.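

In this assay, hydroxymethyl in place of carboxy on this aromatic carbon gives a 12-fold lower number from compound 2 to compound 3 (1.06 log units; beyond the scatter), so the loss does not follow from the count of one hydrogen-bond donor and one hydrogen-bond acceptor, which the two groups share. Hydroxymethyl in place of 1,3-thiazol-2-yl gives a 1.8-fold higher number from compound 1 to compound 3 (0.25 log units; within the scatter), so these two very different groups cannot be told apart here, and among the three compounds only carboxy stands apart. No evidence given explains these differences. Going by these compounds, whether an amine, a primary amide or a methyl ether here would stay with compound 1 and compound 3 or move toward compound 2 remains open.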